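The compounds below may be only part of what the source reports. "The series", "measured", "known", "first", "only" and "open" are said of these compounds alone.

Working notes on the series.

Compound 1 `CC1CCN(C(=O)CCCNC(=O)c2ccc(S(C)(=O)=O)c([N+](=O)[O-])c2)CC1` and compound 2 `CC1CCN(C(=O)CCNC(=O)c2ccc(S(C)(=O)=O)c([N+](=O)[O-])c2)CC1` share the core with compound 3 `CS(=O)(=O)c1ccc(C(=O)NCCCC(=O)N2Cc3ccccc3C2)cc1[N+](=O)[O-]` and differ from one another only in the chain that carries the terminal amide. In an assay on isolated protein for inhibition of thyroid hormone receptor beta (Homo sapiens), read by fluorescence polarization (on this read-out lower numbers stand for stronger inhibition and higher numbers for weaker inhibition), compound 1 gives > 60000 nM, which is a limit of the assay and not a number. Compound 2 likewise reaches only the limit > 60000 nM in this assay. Compound 3 gives > 60000 nM in this assay, again a limit. The step from compound 1 to compound 3, a step that the two limits leave unreadable from compound 1 to compound 3, is therefore not readable in size, and all three values sit at the same limit (the limit of > 60000 nM in this assay, at which 3 of the 3 values shown sit).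

Compound 4 `CS(=O)(=O)c1ccc(C(=O)NCCCC(=O)N2CCCCC2)cc1[N+](=O)[O-]` follows from compound 3 by the change (a group of 6 heavy atoms (5 carbon, 1 nitrogen; one six-membered non-aromatic ring with 1 hetero atom) in place of a group of 9 heavy atoms (8 carbon, 1 nitrogen; one five-membered non-aromatic ring with 1 hetero atom, one six-membered aromatic ring of carbon only), on a carbonyl carbon). Compound 1 already carries a six-membered ring with one heteroatom on the same carbonyl and stands at the limit, so no reading of this kind of exchange is available from the measured steps. Compound 4 is expected to remain at the limit, with a step that the limit leaves unreadable from compound 3 to compound 4 expected to be unreadable and an estimated value of 100000 nM, between 40000 nM and 300000 nM.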

Compound 4, half-maximal inhibitory concentration: > 60000 nM
Compound 4 was reported as a limit; the forecaster's own chance of this, stated with the estimate: 90%; the middle value is on the limit's open side.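

In this assay compound 4 gives > 60000 nM as a limit and not a number. For the compounds shown here, no step to compound 4 from compound 1, compound 2 or compound 3 can be read: the limit of > 60000 nM in this assay, at which 4 of the 4 values shown sit.

The compounds shown leave open whether any change to the shared core or the terminal amide would give a readable value.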